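The source may hold more compounds than are shown below. What is called first, only, known or untested is meant among the compounds shown, and "the series" means these compounds.

Compound 1, `CC(C)C(c1ccc(-c2ccc3cccc(F)c3c2)[nH]c1=O)N1CCCCC1=O`, gives 6.4 nM in an assay on CHO cells for displacement of a labelled ligand from prostaglandin E2 receptor EP3 subtype (Homo sapiens), read by radioligand binding; on this read-out higher numbers stand for weaker inhibition and lower numbers for stronger inhibition.
Compound 2, `CC(C)C(/C=C1/CCNC1=O)c1ccc(-c2ccc3cccc(F)c3c2)[nH]c1=O`, gives 5.3 nM in this assay.

Of the two numbers shown, compound 2 has the smaller one, but the step of a 1.2-fold lower number from compound 1 to compound 2 (0.08 log units; within the scatter) lies within the scatter, so the two compounds are not separated by this assay. Compound 3, `CC(C)C(/C=C1\CCNC1=O)c1ccc(-c2ccc3cccc(F)c3c2)[nH]c1=O`, differs from compound 2 only in geometry: the two compounds have the same atoms and bonds; at least one stereo element is drawn with a configuration in one of them and without one in the other: 1 of 2 stereo elements differ; a double bond is drawn Z in compound 2 and E in compound 3. Within the data shown here, no measured step bears on such a change. Among the measured compounds shown here, the single step known, a 1.2-fold lower number from compound 1 to compound 2 (0.08 log units; within the scatter), concerns the ring size of the lactam on the saturated chain carbon and not the configuration of the double bond, and it was within the scatter. There is thus no basis for expecting a shift in either direction, only a wide uncertainty. For compound 3 the step of a 1.5-fold higher number from compound 2 to compound 3 (0.18 log units; within the scatter) is expected to stay within the scatter. Compound 3 is therefore estimated at 8 nM in this assay, within 2 nM to 40 nM.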

Compound 3, inhibition constant: 2.2 nM
The estimate for compound 3 lay 3.6-fold (0.56 log units) above the measured number; the range from low to high includes it.
By their numbers in this assay, from the lowest: compound 3; then compounds 2 and 1 (each within the scatter of the next).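

In this assay, the geometry of the double bond turns out to count at this position, whereas the change of ring size alone had not separated compounds: a 2.4-fold lower number from compound 2 to compound 3 (0.38 log units; beyond the scatter). The group with the six-membered non-aromatic ring, indistinguishable from the Z form, is separated from the E form, with a 2.9-fold lower number from compound 1 to compound 3 (0.46 log units; beyond the scatter), so compound 3 gives the lowest number of the three, though only by modest steps. This reading of the geometry carries one reservation: the fact that one of compounds 2 and 3 is drawn with a defined configuration and the other without, at the place where they differ

The compounds shown leave open whether the E form would keep its edge with a six-membered ring carrying the same double bond. They also leave open how an open-chain amide, an amine or a carboxylic acid in place of the ring group would compare.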